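The source may hold more compounds than are shown below. What is called first, only, known or untested is meant among the compounds shown, and "the series" means these compounds.

Compound 1 `Nc1ccc(-c2nc3ccccc3s2)cc1CO` is the reference point. In a functional assay on MCF7 cells (Homo sapiens) for cytotoxicity (on this read-out lower numbers stand for stronger inhibition and higher numbers for weaker inhibition), compound 1 gives 6 nM, the lowest of the three numbers seen so far. Compound 3 `CC(=O)Nc1ccc(-c2nc3cc(O)ccc3s2)cc1Cl` gives 31000 nM in this assay, and compound 2 `CC(=O)Nc1ccc(-c2nc3cccc(O)c3s2)cc1C` gives 48200 nM; both lie far above compound 1, beyond the scatter. Compound 4 `Nc1ccc(-c2nc3ccccc3s2)cc1Cl` has not yet been measured. It differs from compound 1 in a single place: chloro in place of hydroxymethyl on an aromatic carbon. The weak numbers of compound 2 and compound 3 come with several changes at once, so they do not isolate this one exchange. The step is expected to be small, with a 1.2-fold lower number from compound 1 to compound 4 (0.08 log units; within the scatter) in this assay, likely within the scatter in either direction. Compound 4 is therefore expected to give 5 nM in this assay, within a range from 0.5 nM to 50 nM.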

Compound 4, half-maximal inhibitory concentration: < 1 nM
Compound 4: a limit, no number (the forecaster's own chance of this, stated with the estimate: 5%); middle value at least 5.0-fold (0.69 log units) away from the limit.
By their numbers in this assay, from the lowest: compound 1; then compounds 3 and 2 (each within the scatter of the next). At a limit, below all of these: compound 4.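

Chloro in place of hydroxymethyl, on the aromatic carbon ortho to an amino group, is the first single change seen here, and it gives an at least 6.0-fold lower number from compound 1 to compound 4 (0.77 log units; beyond the scatter) in this assay. The hydroxymethyl, with its hydrogen-bond donor and acceptor, is therefore not required at this position for a low number. Compound 4 stands at a limit of this assay, < 1 nM, so the step has no upper bound: the limit of < 1 nM in this assay, at which 1 of the 4 values shown sits.

On these data alone, whether bromo, methoxy or a nitrile at this position would match chloro remains open. So does the effect of acetylating the amino group alone, since compound 2 and compound 3 each differ from compound 4 in more than one place.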